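The source may report more compounds than this note shows. Statements on the series, on what has been measured and on what is new or still open speak of the compounds shown alone.

Working notes on the series start from compound 1 `COc1cc(NC(=O)/C=C/c2cccc(O)c2)cc(OC)c1OC` and its one measured number. Among the compounds with values here, in a functional assay on HeLa cells (Homo sapiens) for cytotoxicity, read by sulforhodamine B assay, with a stated time of 72 h (a higher number here means a weaker inhibitor, a lower number a stronger inhibitor), compound 1 gives 18700 nM and stands as the only compound with an actual value so far. Compound 2 `COc1cc(/C=C/C(=O)Nc2cc(OC)c(OC)c(OC)c2)cc(OC)c1OC` reaches only a limit of the assay, > 50000 nM in this read-out. Within the data shown here, that leaves a single number to build on and no pair of measured compounds differing in one place.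

Compound 3 `COc1cc(NC(=O)/C=C/c2cccc(OCc3ccccc3)c2)cc(OC)c1OC` has not yet been measured. It differs from compound 1 by one change, benzyl in place of hydrogen on an oxygen on an aromatic ring in words a benzyl in place of hydrogen on an oxygen on an aromatic ring, or hydroxy to benzyloxy, with the rest of the structure unchanged.

Among the measured compounds shown here, no measured step speaks to this change. The expectation therefore rests on compound 1 at 18700 nM as the sole anchor. The estimated 1.2-fold lower number from compound 1 to compound 3 (0.10 log units; within the scatter) is expected to stay within the scatter, with no firm direction, and the uncertainty is wide. In this assay compound 3 is estimated at 15000 nM with an expected range from 4000 nM to 50000 nM for the coming measurement.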

Compound 3, half-maximal inhibitory concentration: 2100 nM
Compound 3: middle estimate off by 7.1-fold (0.85 log units), on the high side; measured number below the stated range.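

Benzyl in place of hydrogen on an oxygen on an aromatic ring gives an 8.9-fold lower number from compound 1 to compound 3 (0.95 log units; beyond the scatter) in this assay and is the first measured step in the series, one that lies beyond the scatter. This position therefore takes a far larger group than hydrogen, with 7 heavy atoms and a six-membered aromatic ring, and compound 3 shows that the free hydroxy is not required for a lower number in this read-out, at least on the core of compound 1. Nothing shown here explains the size of this step, and the other compound in the series offers no comparison that bears on this change.

A single step cannot separate what is lost with the hydroxy hydrogen from what is gained with the benzyl ring, and a small methoxy or a plain ethoxy on the same oxygen would start to divide the two. Also open, from the compounds shown here alone, is whether the lower number depends on the ring itself or on its distance from the oxygen, which a phenethyl chain, a fluorobenzyl or a benzyl carrying an amine on the same oxygen could test.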